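Replacing the Benzothiazole Fluorines with a Carboxylic Acid

The compounds below may be only part of what the source reports. "The series", "measured", "known", "first", "only" and "open" are said of these compounds alone.

Compound 1 `O=c1cc(-c2ccccc2)oc2cc(OCCCCNc3nc4ccccc4s3)cc(O)c12` gives 4.75 ug/mL in a functional assay on HeLa cells (Homo sapiens) for cytotoxicity, read by sulforhodamine B assay, with a stated time of 48 h; a lower number here means a stronger inhibitor, a higher number a weaker inhibitor.
Compound 2 `O=c1cc(-c2ccccc2)oc2cc(OCCCCNc3nc4ccc(F)cc4s3)cc(O)c12` gives 5.03 ug/mL in this assay.
Compound 3 `O=c1cc(-c2ccccc2)oc2cc(OCCCCNc3nc4c(F)cc(F)cc4s3)cc(O)c12` gives 5.56 ug/mL in this assay.

All three share the same core and differ only in the fluorine count on the benzothiazole ring. The steps between them are small: a 1.1-fold higher number from compound 1 to compound 2 (0.02 log units; within the scatter), a 1.1-fold higher number from compound 2 to compound 3 (0.04 log units; within the scatter) and a 1.2-fold higher number from compound 1 to compound 3 (0.07 log units; within the scatter). Compound 3 therefore shows the highest number of the three, but its distance to the other two lies within the scatter, so no real difference among them can be claimed.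

Compound 4 `O=C(O)c1ccc2nc(NCCCCOc3cc(O)c4c(=O)cc(-c5ccccc5)oc4c3)sc2c1` introduces a different kind of change: 6-carboxy-1,3-benzothiazol-2-yl in place of 4,6-difluoro-1,3-benzothiazol-2-yl on an amine nitrogen. Unlike the earlier steps, which swapped hydrogen for fluorine on the benzothiazole ring, this step removes both fluorines and adds a carboxylic acid, which brings a hydrogen-bond donor and a further acceptor. Within the data shown here, none of the measured steps covers such a change; they only show that fluorine on that ring barely moves the number. Among the measured compounds shown here, with no direct precedent, the expectation for compound 4 is a result close to compound 3, with a wider range for uncertainty, that is a 1.2-fold higher number from compound 3 to compound 4 (0.07 log units; within the scatter). Compound 4 is thus estimated at 6.5 ug/mL, between 3 ug/mL and 15 ug/mL.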

Compound 4, half-maximal inhibitory concentration: 8.43 ug/mL
Compound 4: the middle estimate sits 1.3-fold (0.11 log units) below what was measured; the range from low to high includes it.
By their numbers in this assay, from the lowest: compounds 1, 2, 3 and 4 (each within the scatter of the next).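

Among these compounds, on the benzothiazole ring, the earlier compounds covered only hydrogen and fluoro, whereas compound 4 carries a carboxy group, a much larger change that adds a hydrogen-bond donor. Even so, this assay reveals no real difference: the replacement of both fluorines gives a 1.5-fold higher number from compound 3 to compound 4 (0.18 log units; within the scatter), carboxy in place of fluoro gives a 1.7-fold higher number from compound 2 to compound 4 (0.22 log units; within the scatter), and carboxy in place of hydrogen gives a 1.8-fold higher number from compound 1 to compound 4 (0.25 log units; within the scatter), so this place on the ring accepts a carboxylic acid as well as hydrogen or fluoro without a difference that can be claimed, although these are the largest steps in the set. Nothing in hand explains this result, and no supporting measurement bears on it.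

The compounds shown leave open whether a methyl ester, an amide or an amine at this place would also fall within the scatter of these four, or whether one of them would give a clearly lower number. They also leave open whether a longer chain between the amine nitrogen and the shared core would matter more than any substituent on the benzothiazole ring.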